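The source may report more compounds than this note shows. Statements on the series, on what has been measured and on what is new or still open speak of the compounds shown alone.

Compound 1 `COc1cc(C)cc(-c2c(-c3ccnc(-c4ccc(C(C)=O)cc4)c3)cnn2CC#N)c1` carries an acetyl group. In a functional assay on HCT-15 cells (Homo sapiens) for inhibition, read by sulforhodamine B assay, with a stated time of 48 h (a higher number here means that more compound is tolerated, a lower number that less compound is tolerated), compound 1 gives > 100000 nM, which is a limit of the assay rather than a measured number. On the numbers shown, compound 1 stands at that limit (the limit of > 100000 nM in this assay, at which 1 of the 2 values shown sits). Compound 2 `Cc1cc(O)cc(-c2nn(CC#N)cc2-c2ccnc(-c3ccc(Oc4ccccc4)cc3)c2)c1` is the other measured compound, and in this assay compound 2 gives 26100 nM. Compound 3 `COc1cc(C)cc(-c2c(-c3ccnc(-c4ccc(N(C)C)cc4)c3)cnn2CC#N)c1` has not yet been measured; it differs from compound 1 in one place, (dimethylamino in place of acetyl on an aromatic carbon), dimethylamino in place of acetyl on an aromatic carbon. Among the compounds with values here, no measured step of this kind is available, and compound 1 offers only a limit, so the direction is open; a step of modest size, or none beyond the scatter, is expected. Compound 3 is therefore expected to give 80000 nM, with a range from 20000 nM to 300000 nM. This estimate means an expected step of an at least 1.2-fold lower number from compound 1 to compound 3 (0.09 log units; that floor lies within the scatter).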

Compound 3, concentration lethal to 50% of the cells: > 100000 nM
Compound 3 gave a limit, no number; the forecaster's own chance of this, stated with the estimate: 50%; at least 1.2-fold (0.09 log units) between middle value and limit.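

In this assay, within the data shown here, compound 3 gives > 100000 nM, a limit of the assay and not a number, and compound 1 also offers only a limit, so no step between them can be read. The compounds shown leave open whether dimethylamino in place of acetyl changes the read-out at all.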